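Compound 3 and its nearest neighbours

The compounds below may be only part of what the source reports. "The series", "measured", "known", "first", "only" and "open" are said of these compounds alone.

Three measured compounds share a core and a sulfur-containing side chain. Compound 1 `C/N=C(\S)OC[C@H]1OC(n2cnc3c(NC4CCOC4)nc(Cl)nc32)[C@H](O)[C@@H]1O` and compound 2 `CC/N=C(\S)OC[C@H]1OC(n2cnc3c(NC4CCOC4)nc(Cl)nc32)[C@H](O)[C@@H]1O` carry a chlorine that compound 3 `O[C@@H]1[C@@H](CO/C(S)=N/C2CC2)OC(n2cnc3c(NC4CCOC4)ncnc32)[C@@H]1O` lacks. In an assay on DDT1 cells (Cricetulus griseus) for binding affinity to adenosine receptor A1 (Homo sapiens), read by radioligand binding (on this read-out lower numbers stand for stronger inhibition and higher numbers for weaker inhibition), compound 1 gives 71 nM, compound 2 gives 55 nM, and compound 3 gives 157 nM, the highest of the three numbers. The nearest value to compound 3 is that of compound 1, the furthest that of compound 2, and both gaps lie beyond the usual scatter.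

Compound 4 `CN(C)C(=S)OC[C@H]1OC(n2cnc3c(NC4CCOC4)ncnc32)[C@H](O)[C@@H]1O` differs from compound 3 only in the side chain: a group of 5 heavy atoms (3 carbon, 1 nitrogen, 1 sulfur; no ring) in place of a group of 6 heavy atoms (4 carbon, 1 nitrogen, 1 sulfur; one three-membered non-aromatic ring of carbon only), on an oxygen on a saturated carbon. The change removes the three-membered non-aromatic ring and the hydrogen-bond donor while keeping the sulfur and the double bond. Going by the values given here, the only measured step that touches this side chain is a 1.3-fold lower number from compound 1 to compound 2 (0.11 log units; within the scatter), a small alteration that did not move the number beyond the scatter. That step changed just one chain carbon, whereas the present change is larger, so its outcome is less certain. Compound 4 is therefore expected to land near compound 3, with an estimated step of a 1.4-fold higher number from compound 3 to compound 4 (0.15 log units; within the scatter). The estimate for compound 4 in this assay is 220 nM, with a range from 80 nM to 600 nM.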

Compound 4, inhibition constant: 205 nM
Compound 4: middle estimate off by 1.1-fold (0.03 log units), on the high side; the measured number falls inside the stated range.
By their numbers in this assay, from the lowest: compounds 2 and 1 (each within the scatter of the next); then compounds 3 and 4 (each within the scatter of the next).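

Swapping the cyclopropyl-bearing group of 6 heavy atoms for the open group of 5 heavy atoms gives a 1.3-fold higher number from compound 3 to compound 4 (0.12 log units; within the scatter) in this assay, so a change far larger than the single added methyl of the earlier step also stays inside the scatter. At this place, on an oxygen on a saturated carbon, the three-membered non-aromatic ring and the hydrogen-bond donor can therefore be removed together with no clear shift in the number, at least on the core without chlorine that compound 3 and compound 4 share. No measured evidence comes with these compounds to explain why the number holds so steady.

Because the ring and the donor leave in a single step, the compounds shown cannot say how each loss would count alone, or whether the two might offset each other. Also open, as far as these compounds go, is how the same swap would read on the chlorine-bearing core of compound 1, and whether a much bulkier group at this place, such as a phenyl ring or a longer chain ending in an amine, would stay within the scatter too.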